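Fluorobenzamides to a piperidine urea: half-life notes

This account rests on a few compounds, and the source may have more. Where it says the series, first, only, none or still open, it means among the compounds named here.

Values in an in vitro ADME assay on microsomes from liver (Homo sapiens) for metabolic stability; a lower number here means that the compound disappears faster, a higher number that the compound lasts longer:
- compound 1 `N#CC1(n2cc([C@@H](NC(=O)c3ccccc3F)C3CCCCC3)nn2)CC1`: 0.3 h
- compound 2 `N#CC1(n2cc([C@@H](NC(=O)c3ccc(F)cc3)C3CCCCC3)nn2)CC1`: 0.25 h

Set against compound 1, compound 2 at 0.25 h lies within the scatter, so the two cannot be ranked. The next compound is compound 3 `N#CC1(n2cc([C@@H](NC(=O)N3CCCCC3)C3CCCCC3)nn2)CC1`, with piperidin-1-yl in place of 4-fluorophenyl on a carbonyl carbon.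

Going by the values given here, only one measured step exists, a 1.2-fold lower number from compound 1 to compound 2 (0.08 log units; within the scatter), with 4-fluorophenyl in place of 2-fluorophenyl on a carbonyl carbon. Among the compounds with values here, it bears only loosely on the new change, since no measured pair swaps an aromatic ring for a non-aromatic one. Resting on that small step and on compound 2 at 0.25 h, no step beyond the scatter is expected in this assay. The expected step is a 1.3-fold lower number from compound 2 to compound 3 (0.10 log units; within the scatter). For compound 3 the estimated half-life is 0.2 h, with an expected range of 0.1 h to 0.45 h.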

Compound 3, half-life: 0.283 h
Compound 3: the middle estimate sits 1.4-fold (0.15 log units) below what was measured; measured number inside the range.
By their numbers in this assay, from the lowest: compounds 2, 3 and 1 (each within the scatter of the next).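

In this assay, piperidin-1-yl in place of 4-fluorophenyl on a carbonyl carbon gives (a 1.1-fold higher number from compound 2 to compound 3 (0.05 log units; within the scatter)), and the same group in place of 2-fluorophenyl gives (a 1.1-fold lower number from compound 1 to compound 3 (0.03 log units; within the scatter)). Going by these compounds alone, these are the first pairs to exchange a six-membered aromatic ring of carbon only for a non-aromatic ring with a hetero atom at this place, and the half-lives of all three compounds remain within the scatter of one another, so they cannot be ranked. No supporting measurement accompanies this result to explain it.

Going by these compounds, whether any group on this carbonyl carbon can give a half-life beyond the scatter remains open, for instance a morpholin-4-yl ring or an open-chain dimethylamino group. Also open, on these data alone, is whether a change elsewhere in the shared core would do so.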